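Trading One Triazole for Another on a Shared Core

The compounds below may be only part of what the source reports. "The series", "measured", "known", "first", "only" and "open" are said of these compounds alone.

In a functional assay on the whole organism for inhibition, with Rattus norvegicus as the target, read by paw edema (on this read-out higher numbers stand for an effect only at larger amounts of compound and lower numbers for an effect already at smaller amounts), three compounds share one core and differ only in a five-membered ring on an aromatic carbon. Compound 1 `O=C(O)c1cc(-c2c[nH]cn2)ccc1O` gives 100 mg/kg, compound 2 `O=C(O)c1cc(C2N=NN=N2)ccc1O` gives 110 mg/kg, and compound 3 `O=C(O)c1cc(-n2nccn2)ccc1O` gives 150 mg/kg. Compound 3 therefore stands level with the other two, since repeat measurements of this kind scatter by as much as these gaps.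

The next structure is compound 4 `O=C(O)c1cc(-n2cncn2)ccc1O`, which has the same atoms as compound 3, joined differently. It carries 1H-1,2,4-triazol-1-yl in place of 2H-1,2,3-triazol-2-yl, at the same place: para to a hydroxy group and meta to a carboxy group. The count of the change is 1H-1,2,4-triazol-1-yl in place of 2H-1,2,3-triazol-2-yl on an aromatic carbon.

Within the data shown here, no measured pair swaps one triazole for the other, so the nearest guides are the other ring exchanges. These are a 1.5-fold higher number from compound 1 to compound 3 (0.18 log units; within the scatter), a 1.4-fold higher number from compound 2 to compound 3 (0.13 log units; within the scatter) and a 1.1-fold higher number from compound 1 to compound 2 (0.04 log units; within the scatter). None of these three exchanges moved the number beyond the scatter, so a similarly small change is expected here, with no firm direction. The expected step is a 1.2-fold lower number from compound 3 to compound 4 (0.06 log units; within the scatter) in this assay. For compound 4 the estimated value is 130 mg/kg, with an expected range from 65 mg/kg to 260 mg/kg.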

Compound 4, dose for half-maximal effect: 200 mg/kg
Estimate against measurement, compound 4: 1.5-fold (0.19 log units) below; low and high end bracket the measured number.
By their numbers in this assay, from the lowest: compounds 1, 2, 3 and 4 (each within the scatter of the next).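

Swapping one triazole for the other keeps the same atoms and the same counts of donors and acceptors, and only rearranges the ring, on the aromatic carbon para to a hydroxy group and meta to a carboxy group. In this assay this gives a 1.3-fold higher number from compound 3 to compound 4 (0.12 log units; within the scatter) and so cannot be told apart from no change. This is new information. The earlier compounds shown here held no such pair of isomers. The comparisons with the other two rings, a 1.8-fold higher number from compound 2 to compound 4 (0.26 log units; within the scatter) and a 2.0-fold higher number from compound 1 to compound 4 (0.30 log units; within the scatter), also stay within the scatter, so all four five-membered rings at this position read as level, and no measurement at hand speaks to what lies behind these numbers.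

On these data alone, all four groups here are five-membered rings containing nitrogen, so it remains open whether a phenyl ring, an amine or a longer chain on the same carbon would move the number beyond the scatter. The hydroxy and carboxy groups stay fixed throughout, which leaves their own contribution to the effect on paw swelling unknown.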